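This account rests on a few compounds, and the source may have more. Where it says the series, first, only, none or still open, it means among the compounds named here.

Compound 1 `CCCC(=O)Nc1ccc(Oc2cccc(OC)c2)cc1` gives 0.75 nM in an assay on isolated protein for binding affinity to melatonin receptor type 1B (Homo sapiens) (on this read-out lower numbers stand for stronger inhibition and higher numbers for weaker inhibition), whereas compound 2 `CCC(=O)Nc1ccc(Oc2cccc(OC)c2)cc1` gives 6.8 nM. For the measured compounds named here, the only change between them is methyl in place of hydrogen on a saturated chain carbon, two bonds along the chain from a carbonyl carbon, and it made a 9.1-fold lower number from compound 2 to compound 1 (0.96 log units; beyond the scatter). Compound 3 `CCC(=O)Nc1ccc(N(C)c2cccc(OC)c2)cc1` gives 0.17 nM; how its core differs from that of compound 2 is not broken down here. Compound 4 `COc1cccc(N(C)c2ccc(NC(=O)C(C)C)cc2)c1` has not been measured; it differs from compound 3 by methyl in place of hydrogen on a saturated chain carbon bound to a carbonyl carbon and a saturated chain carbon. Going by the values given here, this is the same kind of change as the one from compound 2 to compound 1, but not the same: there the added methyl sat two bonds along the chain from a carbonyl carbon, reading as ethyl to propyl, while here it sits on a saturated chain carbon bound to a carbonyl carbon and a saturated chain carbon, reading as ethyl to isopropyl. Resting on the step from compound 2 to compound 1, a smaller gain is expected, a 1.7-fold lower number from compound 3 to compound 4 (0.23 log units; within the scatter). Compound 4 is therefore estimated at 0.1 nM, roughly between 0.03 nM and 0.5 nM.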

Compound 4, inhibition constant: 5.5 nM
Compound 4: middle estimate off by 55-fold (1.74 log units), on the low side; measured number outside the range, above it.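

In this assay, the added methyl gives a 32-fold higher number from compound 3 to compound 4 (1.51 log units; beyond the scatter), so one added methyl on this chain has no fixed effect that can be carried from one core to another in this series. Set beside the earlier step, it runs the opposite way: the same change on two cores in this assay, a 9.1-fold lower number (0.96 log units; beyond the scatter) from compound 2 to compound 1 and a 32-fold higher number (1.51 log units; beyond the scatter) from compound 3 to compound 4, 290-fold (2.47 log units) apart, beyond the scatter of two such steps

This does not show that the core alone decides the outcome: the methyl also sits on a different carbon in the two steps, giving ethyl to isopropyl here and ethyl to propyl before, and these two pairs cannot separate the two differences.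

The compounds shown leave open how a propyl chain behaves on the core of compound 3 and how isopropyl behaves on the core of compound 1, the pairings that would separate them. Going by these compounds, how a longer chain, such as butyl, behaves on either core also remains open.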